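Replacing the 4-sulfamoylphenyl group of compound 1

The source may hold more compounds than are shown below. What is called first, only, known or untested is meant among the compounds shown, and "the series" means these compounds.

In an ADME assay on microsomes from liver (Homo sapiens) for metabolic stability, read by LC-MS, tested at 1 mM (a higher number here means that the compound lasts longer, a lower number that the compound disappears faster), compound 1 `N#Cc1ccc(F)cc1Cn1c(N2CCC[C@@H](N)C2)nc2c(-c3ccc(S(N)(=O)=O)cc3)c[nH]c2c1=O` gives > 3.33 h, which is a limit of the assay and not a number. In this assay, compound 2 `CS(=O)(=O)c1ccc(-c2c[nH]c3c(=O)n(Cc4cc(F)ccc4C#N)c(N4CCC[C@@H](N)C4)nc23)cc1F` gives > 3.33 h, also a limit. Together they form (the limit of > 3.33 h in this assay, at which 2 of the 2 values shown sit). Compound 3 `CS(=O)(=O)c1ccccc1-c1c[nH]c2c(=O)n(Cc3cc(F)ccc3C#N)c(N3CCC[C@@H](N)C3)nc12` differs from compound 1 by 2-(methylsulfonyl)phenyl in place of 4-sulfamoylphenyl on an aromatic carbon, with 2-(methylsulfonyl)phenyl in place of 4-sulfamoylphenyl on an aromatic carbon of the shared core. The nearest measured change is a step that the two limits leave unreadable from compound 1 to compound 2, so it provides no size to carry over. With only compound 2 to go on, no step beyond the usual scatter is expected in this assay, and compound 3 may again be reported only as a limit. The estimated step is a step that the limit leaves unreadable from compound 1 to compound 3. For compound 3 the expected half-life is 4 h, with an estimated range of 1.5 h to 8 h.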

Compound 3, half-life: > 3.33 h
Compound 3: only a limit was reported; the forecaster's own chance of this, stated with the estimate: 65%; the middle value does not contradict the limit.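

In this assay compound 3 gives > 3.33 h, a limit and not a number. The steps among compound 1, compound 2 and compound 3 cannot be read: the limit of > 3.33 h in this assay, at which 3 of the 3 values shown sit.

The compounds shown leave open how long each lasts and whether exchanging these aryl groups alters the half-life at all.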